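Replacing a cyclic ether with a fluorinated chain

The source may report more compounds than this note shows. Statements on the series, on what has been measured and on what is new or still open speak of the compounds shown alone.

Compound 2 `CCc1nn2c(-c3c(C)cc(C)cc3OC)cccc2c1N(CC1CC1)CC1CCOC1` stands, in an assay on HEK293 cells for displacement of a labelled ligand from corticotropin-releasing factor receptor 1 (Homo sapiens), read by scintillation counting, with a stated time of 2 h (a lower number here means a stronger inhibitor, a higher number a weaker inhibitor), at the higher of the two numbers shown, with 38 nM; compound 1 `CCc1nn2c(-c3c(C)cc(C)cc3OC)cccc2c1N(CC1CCOCC1)CC1CC1` gives 22 nM, and the step of a 1.7-fold higher number from compound 1 to compound 2 (0.24 log units; within the scatter) is the only one measured. Compound 3 `CCc1nn2c(-c3c(C)cc(C)cc3OC)cccc2c1N(CCCF)CC1CC1` differs from compound 2 by 2-fluoroethyl in place of oxolan-3-yl on a saturated chain carbon bound to a nitrogen on an aromatic ring. No measured step covers loss of the ring, so the single step shown is only a weak guide, and no shift beyond the scatter is expected. Compound 3 is therefore estimated at 50 nM, within 18 nM to 150 nM, a step of a 1.3-fold higher number from compound 2 to compound 3 (0.12 log units; within the scatter).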

Compound 3, half-maximal inhibitory concentration: 20 nM
Compound 3: middle estimate off by 2.5-fold (0.40 log units), on the high side; measured number inside the range.
By their numbers in this assay, from the lowest: compounds 3, 1 and 2 (each within the scatter of the next).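

In this assay, 2-fluoroethyl, which has no ring and no hydrogen-bond acceptor, reads level with both cyclic ethers at this place (a 1.9-fold lower number from compound 2 to compound 3 (0.28 log units; within the scatter)) and (a 1.1-fold lower number from compound 1 to compound 3 (0.04 log units; within the scatter)). So, among these three compounds, neither the ring nor its oxygen is needed to keep the number in this range. No evidence given here explains this result. The compounds shown leave open whether an amine, a carboxylic acid or a longer chain without fluorine would be tolerated at this place, and whether the fluorine itself matters.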